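From a Lactone Ring to a Bare Aldehyde

The source may report more compounds than this note shows. Statements on the series, on what has been measured and on what is new or still open speak of the compounds shown alone.

Compound 1 `C=C1CC[C@@H]2[C@](C)(CO)[C@H](O)CC[C@@]2(C)[C@@H]1CCC1C(=O)OC[C@H]1O`: in a functional assay on BMMC cells (Mus musculus, strain C57BL/6) for inhibition, with stated times of 5 days and 48 h (on this read-out higher numbers stand for weaker inhibition and lower numbers for stronger inhibition), compound 1 gives > 30000 nM, which is a limit of the assay rather than a number.
Compound 2 `C=C1CC[C@@H]2[C@](C)(CO)[C@H](O)CC[C@@]2(C)[C@@H]1C/C=C1\C=COC1=O`: in this assay compound 2 gives 2770 nM.

Among the measured compounds shown here, compound 2 thus holds the only actual number here, since the other value shown is a limit. Compound 3 `C=C1CC[C@@H]2[C@](C)(CO)[C@H](O)CC[C@@]2(C)[C@@H]1CC=O` differs from compound 2 by a group of 2 heavy atoms (1 carbon, 1 oxygen; no ring) in place of a group of 7 heavy atoms (5 carbon, 2 oxygen; one five-membered non-aromatic ring with 1 hetero atom), on a saturated chain carbon bound to a saturated ring carbon. For the measured compounds named here, the single measured step, an at least 10-fold lower number from compound 1 to compound 2 (1.03 log units; beyond the scatter), swapped one five-membered ring for another and does not cover removal of the ring altogether, so it gives no direct guide to the step from compound 2 to compound 3. With the ring gone, the step of a 3.6-fold higher number from compound 2 to compound 3 (0.56 log units; beyond the scatter) is expected to go toward higher numbers in this assay, meaning weaker inhibition, though this rests on little. Compound 3 is therefore estimated at 10000 nM, within 2500 nM to 30000 nM, and the value of compound 1 at the limit of > 30000 nM in this assay, at which 1 of the 2 values shown sits, shows a limit is possible.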

Compound 3, half-maximal inhibitory concentration: > 30000 nM
Compound 3 ended at the assay's limit; the forecaster's own chance of this, stated with the estimate: 30%; middle value at least 3.0-fold (0.47 log units) from the limit.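

The earlier step exchanged one five-membered ring for another, whereas this change removes the ring altogether: putting formyl in its place on the saturated chain carbon gives an at least 10-fold higher number from compound 2 to compound 3 (1.03 log units; beyond the scatter) in this assay, so a bare formyl group at this place does not keep the inhibition seen with compound 2. Compound 3 gives > 30000 nM, which is a limit of the assay and not a number. The step between compound 1 and compound 3 cannot be read, because both values sit at the same limit: the limit of > 30000 nM in this assay, at which 2 of the 3 values shown sit.

Among the compounds shown here, compound 2 therefore remains the only compound here with an actual number, and three compounds cannot show whether its five-membered ring matters as a whole or whether only part of that group does. A carboxylic acid or an amine in place of formyl, or a longer chain ending in formyl, would help separate the length of the chain from the ring itself, and the compounds shown say nothing about any of these groups.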